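This account rests on a few compounds, and the source may have more. Where it says the series, first, only, none or still open, it means among the compounds named here.

Compound 3, `Cn1c(SCc2ccc(Cl)c(Cl)c2)nnc1-c1cc([N+](=O)[O-])cc([N+](=O)[O-])c1`, carries a 3,4-dichlorophenyl group on the saturated chain carbon bound to a sulfur. In an ADME assay on A-431 cells (Homo sapiens) for cytotoxicity, with a stated time of 48 h (on this read-out higher numbers stand for weaker inhibition and lower numbers for stronger inhibition), compound 3 gives > 30000 nM, which is a limit of the assay rather than a number. Compound 1, `Cn1c(SCc2ccc(Br)cc2)nnc1-c1cc([N+](=O)[O-])cc([N+](=O)[O-])c1`, gives > 30000 nM, again a limit. Compound 2, `Cn1c(SCc2ccc(Cl)cc2)nnc1-c1cc([N+](=O)[O-])cc([N+](=O)[O-])c1`, gives > 30000 nM, also a limit. All three sit at the limit of > 30000 nM in this assay, at which 3 of the 3 values shown sit, so a step that the two limits leave unreadable from compound 1 to compound 2, a step that the two limits leave unreadable from compound 1 to compound 3 and a step that the two limits leave unreadable from compound 2 to compound 3 cannot be sized. Compound 4, `O=[N+]([O-])c1cc(-c2nnc(SCc3ccc(Cl)c(Cl)c3)n2Cc2ccccc2)cc([N+](=O)[O-])c1`, differs from compound 3 by phenyl in place of hydrogen on a saturated chain carbon bound to an aromatic nitrogen. Among the measured compounds shown here, no measured step touches this carbon, and the three steps elsewhere gave nothing readable, so no shift beyond the scatter is expected in this assay, a step that the limit leaves unreadable from compound 3 to compound 4. Compound 4 is therefore expected at 40000 nM, within 10000 nM to 100000 nM, most likely again only a limit.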

Compound 4, half-maximal inhibitory concentration: > 30000 nM
Compound 4: a limit, no number (the forecaster's own chance of this, stated with the estimate: 75%); the middle value lies beyond the limit too.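

Compound 3 and compound 4 are both limits rather than numbers, so the step between them cannot be read: the limit of > 30000 nM in this assay, at which 4 of the 4 values shown sit.

Whether any of these changes has an effect in this assay stays open: no compound shown gives an actual number.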